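Moving One Bromine: What to Expect of Compound 4

A few compounds are considered here, and "the series" means these few. Any claim that something is new, unique, unknown or untested is made for them only; others in the source may bear on it.

Measured in a functional assay on HL-60 cells (Homo sapiens) for cytotoxicity, read by luminescence and CellTiter-Glo, with a stated time of 3 days; on this read-out lower numbers stand for stronger inhibition and higher numbers for weaker inhibition
Compound 1 `O=C(Nc1cc(C(F)(F)F)cc(C(F)(F)F)c1)c1ccc(Br)cc1O` gives 270 nM
Compound 2 `O=C(Nc1cc(C(F)(F)F)cc(C(F)(F)F)c1)c1ccc(-c2ccccc2)cc1O` gives 1140 nM
Compound 3 `O=C(Nc1ccc(OC(F)(F)F)c(Cl)c1)c1cc(F)ccc1O` gives 550 nM

Compound 1 has the lowest number of these three. Compound 4 `O=C(Nc1cc(C(F)(F)F)cc(C(F)(F)F)c1)c1cc(Br)ccc1O` has the same atoms joined differently, with 5-bromo-2-hydroxyphenyl in place of 4-bromo-2-hydroxyphenyl on a carbonyl carbon. Among the compounds with values here, the one measured step, a 4.2-fold higher number from compound 1 to compound 2 (0.63 log units; beyond the scatter), put phenyl in place of bromo on an aromatic carbon. It replaced the bromo rather than moving it, so it bears only loosely on this change. Compound 3 differs from compound 1 in more than one place and gives no clean comparison. With so little evidence, no clear direction and no step beyond the scatter is expected in this assay. The estimated step is a 1.1-fold lower number from compound 1 to compound 4 (0.03 log units; within the scatter). For compound 4 the estimated value is 250 nM, with an expected range of 100 nM to 650 nM.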

Compound 4, half-maximal inhibitory concentration: 290 nM
Beside the measured number, compound 4's estimate is 1.2-fold (0.06 log units) below it; the range from low to high includes it.
By their numbers in this assay, from the lowest: compounds 1, 4 and 3 (each within the scatter of the next, the first and the last beyond it); then compound 2.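

In this assay, taking 5-bromo-2-hydroxyphenyl in place of 4-bromo-2-hydroxyphenyl on the carbonyl carbon gives a 1.1-fold higher number from compound 1 to compound 4 (0.03 log units; within the scatter). So, for this pair, the two bromine placements cannot be told apart, whereas swapping the bromo for phenyl gave a 4.2-fold higher number from compound 1 to compound 2 (0.63 log units; beyond the scatter). Nothing available explains why the two placements read alike.

Whether the same holds for other groups stays open: a methoxy group or an amine in place of the bromo of compound 4 could read differently, and the compounds shown do not tell.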